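Replacing a methyl(propyl)amino group by methoxy on the shared core

The source may hold more compounds than are shown below. What is called first, only, known or untested is meant among the compounds shown, and "the series" means these compounds.

Measured compounds:
- compound 1, `CCCN(C)c1nc(N)c(C(=O)N=C(N)N)nc1Cl`: 32%
- compound 2, `CN(c1nc(N)c(C(=O)N=C(N)N)nc1Cl)C1CCCCC1`: "not determined" (no result reported)
- compound 3, `NC(N)=NC(=O)c1nc(Cl)c(Nc2cnc3ccccc3c2)nc1N`: 28%

All three compounds share the same core, an acylguanidine carrying an amino group and a chloro group, and differ in the group attached at one remaining aromatic carbon. In an assay for inhibition of acid-sensing ion channel 3 (Homo sapiens), read by patch clamp, tested at 1 uM (on this read-out higher numbers stand for more inhibition at the one concentration tested (going by the name of the read-out) and lower numbers for less inhibition), compound 1 gives 32% and compound 3 gives 28%. These two numbers lie within the usual scatter of each other, so neither compound can be set above the other on this evidence. In this assay compound 2 gives "not determined" (no result reported), so it adds nothing to the comparison.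

Compound 4, `COc1nc(N)c(C(=O)N=C(N)N)nc1Cl`, has not yet been measured. It differs from compound 1 in one place: methoxy in place of methyl(propyl)amino on an aromatic carbon. The larger methyl(propyl)amino group gives way to a much smaller methoxy group at the same aromatic carbon.

For the measured compounds named here, with no comparable step among the measured compounds, the direction is uncertain. The expected step of a number 10 percentage points lower from compound 1 to compound 4 (within the scatter) is a modest fall, quite possibly not beyond the scatter. For compound 4 the estimated inhibition is 22%, with a likely range from 5% to 42%.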

Compound 4, a percentage reported as inhibition, at one concentration (the size of the read-out at that concentration, not a potency): 21%
Beside the measured number, compound 4's estimate is 1 percentage points above it; the measured number falls inside the stated range.
By their numbers in this assay, from the lowest: compounds 4, 3 and 1 (each within the scatter of the next, the first and the last beyond it).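

In this assay, for the compounds shown here, the swap of methyl(propyl)amino for methoxy on this aromatic carbon brings a number 11 percentage points lower from compound 1 to compound 4 (beyond the scatter), the first step at this position that can be read and one that lies beyond the usual scatter. Going by these compounds alone, compounds 1 and 3 could not show this, as their numbers lie within the scatter of each other, so the group here had not yet been seen to alter the read-out. The change is modest, however: with a group of only 2 heavy atoms at this carbon in place of one with 5, compound 4 still gives 21%, and no measurement of any property of the two groups offers an explanation for the fall.

Going by these compounds, the step from compound 1 to compound 2 cannot be read, so the effect of a cyclohexyl group in place of the propyl chain remains unknown. On these data alone, it also remains open whether the fall follows the smaller group or the oxygen taking the place of nitrogen at the ring, and an ethoxy or a dimethylamino group at the same carbon would help to tell these two apart.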